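The source may report more compounds than this note shows. Statements on the series, on what has been measured and on what is new or still open speak of the compounds shown alone.

Compound 1 `Cn1cncc1CN1CC(N(CC2CCN(C(=O)C(C)(C)C)CC2)S(=O)(=O)c2ccccn2)Cc2cc(C#N)ccc21` is the reference point. In an ADME assay on Caco-2 cells (Homo sapiens) for permeability, in the apical to basolateral direction (a lower number here means that the compound crosses the layer more slowly, a higher number that the compound crosses the layer faster), compound 1 gives 0.5 10^-6 cm/s and sits level with compound 3 `Cn1cncc1CN1CC(N(CC2CCN(C(=O)c3ccco3)CC2)S(=O)(=O)c2ccccn2)Cc2cc(C#N)ccc21` at the digits shown, the two together the lowest of three numbers; compound 3 gives 0.5 10^-6 cm/s. Compound 2 `Cn1cncc1CN1CC(N(CC2CCN(C(=O)N3CCCC3)CC2)S(=O)(=O)c2ccccn2)Cc2cc(C#N)ccc21` gives 0.6 10^-6 cm/s. The measured steps are small: a 1.2-fold higher number from compound 1 to compound 2 (0.08 log units; within the scatter) and no change at the digits printed from compound 1 to compound 3 (within the scatter), both on the carbonyl carbon.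

Compound 4 `Cc1noc(C)c1CN(C1Cc2cc(C#N)ccc2N(Cc2cncn2C)C1)S(=O)(=O)c1ccccn1` differs from compound 1 elsewhere: 3,5-dimethyl-1,2-oxazol-4-yl in place of 1-((tert-butyl)carbonyl)piperidin-4-yl on a saturated chain carbon bound to a sulfonamide nitrogen. Among the compounds with values here, no measured step touches this place; the three known values all keep the piperidinyl part intact and vary only the group on its carbonyl carbon, so they give no direct guide. Working from the narrow band of the three numbers, compound 4 is expected to give 0.9 10^-6 cm/s, range 0.3 10^-6 cm/s to 3 10^-6 cm/s, a step of a 1.8-fold higher number from compound 1 to compound 4 (0.26 log units; within the scatter) that is an estimate only.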

Compound 4, apparent permeability: 8 10^-6 cm/s
Estimate against measurement, compound 4: 8.9-fold (0.95 log units) below, and the stated range ends below it.
By their numbers in this assay, from the lowest: compounds 1, 3 and 2 (each within the scatter of the next); then compound 4.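

Replacing 1-((tert-butyl)carbonyl)piperidin-4-yl with 3,5-dimethyl-1,2-oxazol-4-yl on a saturated chain carbon bound to a sulfonamide nitrogen gives a 16-fold higher number from compound 1 to compound 4 (1.20 log units; beyond the scatter) in this assay and shows that this position can move the number well beyond the scatter. The changes on the carbonyl carbon gave no sign of this. Nothing at hand explains the step.

Still open, on these data alone, is whether the aromatic ring or the removal of the acylated piperidine accounts for the step. A phenyl group or a free piperidin-4-yl amine at this place would help separate the two.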